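Nitro in Place of Hydrogen on the Aromatic Ring of Compound 1

A few compounds are considered here, and "the series" means these few. Any claim that something is new, unique, unknown or untested is made for them only; others in the source may bear on it.

Compound 1 `CC1=CC[C@H](C(C)(C)NC(=S)N/N=C/c2ccccc2)CC1` gives 20600 nM in a functional assay on OVCAR-3 cells (Homo sapiens) for inhibition, read by sulforhodamine B assay, with a stated time of 48 h (a higher number here means a weaker inhibitor of growth, a lower number a stronger inhibitor of growth), the lowest of the two plain numbers shown, with compound 2 `COc1ccc(/C=N/NC(=S)NC(C)(C)[C@H]2CC=C(C)CC2)cc1` close by at 21200 nM. Compound 3 `CC1=CC[C@H](C(C)(C)NC(=S)N/N=C/c2ccc(N(C)C)cc2)CC1` sits at the limit of > 100000 nM in this assay, at which 1 of the 3 values shown sits, so its result of > 100000 nM is a limit of the assay rather than a number.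

Two kinds of change on this ring have been measured. The step of a 1.0-fold higher number from compound 1 to compound 2 (0.01 log units; within the scatter) shows that methoxy in place of hydrogen leaves the number where it was. The steps of an at least 4.8-fold higher number from compound 1 to compound 3 (0.68 log units; beyond the scatter) and an at least 4.7-fold higher number from compound 2 to compound 3 (0.67 log units; beyond the scatter) show that dimethylamino weakens growth inhibition.

Compound 4 `CC1=CC[C@H](C(C)(C)NC(=S)N/N=C/c2ccccc2[N+](=O)[O-])CC1` differs from compound 1 by nitro in place of hydrogen on an aromatic carbon. Going by the values given here, no measured step concerns a nitro group, so the bearing of the earlier steps is indirect; only the methoxy step speaks for a small substituent leaving the number unchanged. Compound 4 is therefore expected to show a step of a 1.1-fold lower number from compound 1 to compound 4 (0.06 log units; within the scatter), within the scatter. The estimate for compound 4 is 18000 nM, with a range from 7000 nM to 50000 nM.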

Compound 4, concentration for total growth inhibition: 25800 nM
Estimate against measurement, compound 4: 1.4-fold (0.16 log units) below; measured number inside the range.
By their numbers in this assay, from the lowest: compounds 1, 2 and 4 (each within the scatter of the next). At a limit, above all of these: compound 3.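

In this assay the step of a 1.3-fold higher number from compound 1 to compound 4 (0.10 log units; within the scatter) comes from nitro in place of hydrogen, ortho to a large group, and so this change leaves the number where it was. The earlier compounds shown here carried no substituent at this place on the ring, and the result shows that a nitro group can stand here without moving the number away from that of compound 1. Compound 3 remains the only compound at a limit of the assay: the limit of > 100000 nM in this assay, at which 1 of the 4 values shown sits.

The compounds shown leave open whether an amine, a hydroxyl group or a carboxylic acid at this same place would also leave the number unchanged. They also leave open whether methoxy or dimethylamino, ortho to a large group, would behave as they do in compound 2 and compound 3.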